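A benzyloxycarbonyl group added to a flat series

This account rests on a few compounds, and the source may have more. Where it says the series, first, only, none or still open, it means among the compounds named here.

Measured in a functional assay on MCF7 cells (Homo sapiens) for antiproliferative activity, read by MTT assay, with a stated time of 48 h (a higher number here means a weaker inhibitor, a lower number a stronger inhibitor), so far
Compound 1 `c1ccc(-c2nn(-c3ccccc3)cc2-c2nc3ccccc3[nH]2)cc1` gives 3190 nM
Compound 2 `Fc1ccc2[nH]c(-c3cn(-c4ccccc4)nc3-c3ccccc3)nc2c1` gives 2430 nM
Compound 3 `FC(F)(F)c1ccc2[nH]c(-c3cn(-c4ccccc4)nc3-c3ccccc3)nc2c1` gives 2660 nM

Compound 1 stands level with the other two compounds: a 1.3-fold lower number from compound 1 to compound 2 (0.12 log units; within the scatter) and a 1.2-fold lower number from compound 1 to compound 3 (0.08 log units; within the scatter) both lie within the scatter. Compound 4 `O=C(OCc1ccccc1)c1ccc2[nH]c(-c3cn(-c4ccccc4)nc3-c3ccccc3)nc2c1` has benzyloxycarbonyl in place of hydrogen on an aromatic carbon of the core of compound 1, and the change counts as benzyloxycarbonyl in place of hydrogen on an aromatic carbon in full. The two steps to compound 2 and compound 3 bear on this change, as does a 1.1-fold higher number from compound 2 to compound 3 (0.04 log units; within the scatter), which also stays within the scatter. Fluoro and trifluoromethyl are much smaller than benzyloxycarbonyl, so these steps guide the expectation only loosely. No shift beyond the scatter is therefore expected in this assay, in either direction. The expected result is a 1.3-fold lower number from compound 1 to compound 4 (0.11 log units; within the scatter), although this estimate is uncertain. For compound 4 the estimated value is 2500 nM, with an expected range from 900 nM to 7000 nM.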

Compound 4, half-maximal inhibitory concentration: 12600 nM
The estimate for compound 4 lay 5.0-fold (0.70 log units) below the measured number; measured number outside the range, above it.
By their numbers in this assay, from the lowest: compounds 2, 3 and 1 (each within the scatter of the next); then compound 4.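

In this assay this position no longer looks indifferent to what it carries: fluoro and trifluoromethyl left the number within the scatter, whereas benzyloxycarbonyl gave a 3.9-fold higher number from compound 1 to compound 4 (0.60 log units; beyond the scatter) and also a 4.7-fold higher number from compound 3 to compound 4 (0.68 log units; beyond the scatter) and a 5.2-fold higher number from compound 2 to compound 4 (0.71 log units; beyond the scatter) in the comparisons with those two groups. Of the changes shown at this position, this is the only one that moves the number beyond the scatter, and it moves it towards a weaker inhibitor. No measurement shown accounts for this shift. From the compounds shown here alone, whether a carboxylic acid or a methyl ester here would also raise the number remains open. So does whether any group at this position can lower it beyond the scatter.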